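Swapping dimethylamino for acetyl

This account rests on a few compounds, and the source may have more. Where it says the series, first, only, none or still open, it means among the compounds named here.

In a functional assay on B16-F0 cells (Mus musculus) for inhibition, read by CCK-8 assay, with a stated time of 48 h (a lower number here means a stronger inhibitor, a higher number a weaker inhibitor), compound 1 `COc1cc(-c2ccnc3cc(-c4cn(C)c5ccccc45)nn23)cc(OC)c1OC` gives 185 nM, while compound 2 `COc1cc(-c2ccnc3cc(-c4ccc(N(C)C)cc4)nn23)cc(OC)c1OC` gives 702 nM, the higher of the two numbers. Compound 3 `COc1cc(-c2ccnc3cc(-c4ccc(C(C)=O)cc4)nn23)cc(OC)c1OC` has acetyl in place of dimethylamino on an aromatic carbon, para to a large group: acetyl in place of dimethylamino on an aromatic carbon. Within the data shown here, the only measured step, a 3.8-fold higher number from compound 1 to compound 2 (0.58 log units; beyond the scatter), is modest and changes a different group, so it bears only loosely on this swap. A small step in this assay is therefore expected, perhaps towards a higher number and possibly none beyond the scatter. The expected step is a 1.4-fold higher number from compound 2 to compound 3 (0.15 log units; within the scatter). Compound 3 is estimated at 1000 nM, with a range of 300 nM to 3500 nM.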

Compound 3, half-maximal inhibitory concentration: 3930 nM
Beside the measured number, compound 3's estimate is 3.9-fold (0.59 log units) below it; the measured number lies above the stated range.
By their numbers in this assay, from the lowest: compound 1; then compound 2; then compound 3.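

At this position the group matters even when its size in heavy atoms stays the same: acetyl in place of dimethylamino gives a 5.6-fold higher number from compound 2 to compound 3 (0.75 log units; beyond the scatter) in this assay and is not the small step a like-for-like swap might suggest. Replacing the whole substituent gives a larger change, with 4-acetylphenyl in place of 1-methyl-1H-indol-3-yl giving a 21-fold higher number from compound 1 to compound 3 (1.33 log units; beyond the scatter) in the same assay. No measurement here explains either step. Still open, going by these compounds, is where other groups in this place, such as a primary amine, a methoxy group or a carboxylic acid, would fall relative to acetyl and dimethylamino.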